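The compounds below may be only part of what the source reports. "The series", "measured", "known", "first", "only" and "open" are said of these compounds alone.

In a functional assay on RAW264.7 cells (Mus musculus) for inhibition, read by Griess assay, with stated times of 1 h and 24 h (on this read-out lower numbers stand for stronger inhibition and higher numbers for weaker inhibition), three compounds have been measured so far. Compound 1 `Cc1noc(CC2OC(=O)c3ccccc32)n1` gives > 10000 nM, which is a limit of the assay and not a number. Compound 2 `O=C1OC(Cc2nc(-c3ccc(Oc4ccccc4)cc3)no2)c2ccccc21` gives > 10000 nM, again a limit. Compound 3 `COc1ccc(C(O)C2OC(=O)c3c(OC)cc(OC)cc32)cc1` gives > 10000 nM, also a limit. Compound 3 therefore has no exact number to place it, and the picture so far is the limit of > 10000 nM in this assay, at which 3 of the 3 values shown sit. Compound 4 `CCCOc1ccc(C(O)C2OC(=O)c3c(OC)cc(OC)cc32)cc1` carries one change: ethyl in place of hydrogen on a saturated chain carbon bound to an oxygen on an aromatic ring, so methoxy becomes propoxy. For the measured compounds named here, no measured step between two compounds is available as a guide, so no step beyond the usual scatter in this assay is expected. The expected change is a number no higher from compound 3 to compound 4 (the limit leaves the size open). The estimated value for compound 4 is 10000 nM, with an expected range from 4000 nM to 25000 nM.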

Compound 4, half-maximal inhibitory concentration: 9260 nM
Estimate against measurement, compound 4: 1.1-fold (0.03 log units) above; low and high end bracket the measured number.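

In this assay, for the compounds shown here, compound 4 gives 9260 nM, the first exact number in this set. As far as these compounds go, changing methoxy to propoxy gives an at least 1.0-fold lower number from compound 3 to compound 4 (0.03 log units; that floor lies within the scatter); the start of this step is only a limit, so its true size remains unknown, and the printed floor alone does not establish a real gain. Most of the set still stays at the ceiling: the limit of > 10000 nM in this assay, at which 3 of the 4 values shown sit.

From the compounds shown here alone, whether a longer chain, such as butoxy or hexyloxy, would move the number further remains open. So does the effect of an amine at the end of the chain.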